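Compound 4 and the ring change on the urea nitrogen

The source may report more compounds than this note shows. Statements on the series, on what has been measured and on what is new or still open speak of the compounds shown alone.

Three ureas sharing one core have been measured. In a functional assay on T-24 cells (Homo sapiens) for antiproliferative activity, read by MTT assay, with a stated time of 48 h (a lower number here means a stronger inhibitor, a higher number a weaker inhibitor), compound 1 `O=C(Nc1cccc(CNc2nccnc2Cl)c1)Nc1ccc(Cl)cc1Br` gives 6650 nM, compound 2 `O=C(Nc1ccc(Cl)cc1)Nc1cccc(CNc2nccnc2Cl)c1` gives 5470 nM, and compound 3 `CC(C)(C)c1ccc(NC(=O)Nc2cccc(CNc3nccnc3Cl)c2)cc1` gives 6010 nM. Compound 2 carries the smallest of the three numbers, but neither neighbour is separated from it beyond the scatter: a 1.2-fold lower number from compound 1 to compound 2 (0.08 log units; within the scatter), and a 1.1-fold higher number from compound 2 to compound 3 (0.04 log units; within the scatter). Compound 4 `O=C(Nc1cccc(CNc2nccnc2Cl)c1)Nc1ccc(F)c(Cl)c1` has not yet been measured in this assay. It differs from compound 2 in one place: 3-chloro-4-fluorophenyl in place of 4-chlorophenyl on an amide-type nitrogen. Both measured steps changed the substitution of the same ring on the urea nitrogen, and both were too small to count. For the measured compounds named here, no step adds a fluorine to that ring, so the expectation rests on these two small steps alone, and a step of no clear size in either direction is expected in this assay. Compound 4 is therefore estimated at 5500 nM, with a range from 2700 nM to 11000 nM, meaning an expected 1.0-fold higher number from compound 2 to compound 4 (0.00 log units; within the scatter).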

Compound 4, half-maximal inhibitory concentration: 4990 nM
Compound 4: the middle estimate sits 1.1-fold (0.04 log units) above what was measured, within the range that was stated.
By their numbers in this assay, from the lowest: compounds 4, 2, 3 and 1 (each within the scatter of the next).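

In this assay, the 3-chloro-4-fluorophenyl group of compound 4 brings a fluorine onto the ring on the urea nitrogen for the first time among these compounds, and the step stays within the scatter (a 1.1-fold lower number from compound 2 to compound 4 (0.04 log units; within the scatter)). Compared with the 2-bromo-4-chlorophenyl group, the change is likewise not separated from the scatter (a 1.3-fold lower number from compound 1 to compound 4 (0.12 log units; within the scatter)), so bromo, chloro, fluoro and tert-butyl substitution on this ring all give numbers that cannot be told apart across these four compounds. No measurement is available to explain why these numbers lie so close together.

The rings shown carry only halogens or tert-butyl, so the effect of an amine or a carboxylic acid on this ring remains open. From the compounds shown here alone, the shared core is the same throughout, so replacing its chloro with an amine also remains untested here.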